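The source may report more compounds than this note shows. Statements on the series, on what has been measured and on what is new or still open speak of the compounds shown alone.

Three related compounds have been tested in a functional assay on HL-60 cells (Homo sapiens) for antiproliferative activity, read by MTT assay (on this read-out lower numbers stand for stronger inhibition and higher numbers for weaker inhibition), and none has yet given a plain number. Compound 3 `COc1ccc(/C=N/NC(=O)c2cn(C3CC3)c3cc(N4CCNCC4)c(F)cc3c2=O)cc1O` gives <= 25000 nM, which is a limit. Compound 2 `O=C(N/N=C/c1ccccc1O)c1cn(C2CC2)c2cc(N3CCNCC3)c(F)cc2c1=O` gives <= 25000 nM, also a limit. Compound 1 `O=C(N/N=C/c1ccc(F)cc1)c1cn(C2CC2)c2cc(N/N=C/c3ccc(F)cc3)c(F)cc2c1=O` gives <= 25000 nM, again a limit. The whole picture so far is therefore (the limit of <= 25000 nM in this assay, at which 3 of the 3 values shown sit).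

Compound 4 `O=C(N/N=C/c1ccc(F)cc1)c1cn(C2CC2)c2cc(N3CCNCC3)c(F)cc2c1=O` differs from compound 3 in a single place: 4-fluorophenyl in place of 3-hydroxy-4-methoxyphenyl on a carbon with a double bond to nitrogen. In words, it has 4-fluorophenyl in place of 3-hydroxy-4-methoxyphenyl on a carbon with a double bond to nitrogen.

For the measured compounds named here, the one measured step at this place is a step that the two limits leave unreadable from compound 2 to compound 3. It offers no size to carry over, so no step beyond the scatter is expected in this assay, and no direction is favoured. The estimated step is a step that the limit leaves unreadable from compound 3 to compound 4. Compound 4 is expected near 15000 nM, with an estimated range from 3000 nM to 25000 nM, and it may well report only a limit again.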

Compound 4, half-maximal inhibitory concentration: <= 25000 nM
Compound 4 gave a limit, no number; the forecaster's own chance of this, stated with the estimate: 75%; the middle value does not contradict the limit.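

For the compounds shown here, compound 4 gives only a limit, as do compound 1, compound 2 and compound 3, so no step among them can be read: the limit of <= 25000 nM in this assay, at which 4 of the 4 values shown sit. The compounds shown leave open whether any of these group changes alters the result in this assay, and by how much.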